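The source may hold more compounds than are shown below. What is called first, only, known or untested is meant among the compounds shown, and "the series" means these compounds.

The measured compounds in an ADME assay on L1210/0 cells (Mus musculus) for cytotoxicity, with a stated time of 48 h (a lower number here means a stronger inhibitor, a higher number a weaker inhibitor), are three: compound 1 `CO[C@@H]1OC[C@@H](OC(C)=O)[C@@H](OC(C)=O)[C@]1(F)n1ccc(=O)[nH]c1=O` with 55000 nM, compound 2 `O=c1[nH]c(=O)n([C@H]2C[C@H](O)[C@@H](CO)O2)cc1[N+](=O)[O-]` with 130 nM, and compound 3 `Nc1nc(N)c2nnn([C@H]3CCCC[C@H]3CO)c2n1`.

Compound 2 holds the lowest of the two numbers, and the nearest number, that of compound 1, stands higher by a margin well beyond the scatter. For compound 3 the result, > 200000 nM, is a limit and not a number, in line with the limit of > 200000 nM in this assay, at which 1 of the 3 values shown sits, a limit at which one of the three values sits.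

The unmeasured compound 4 `CCCCCC#Cc1cn([C@H]2C[C@H](O)[C@@H](CO)O2)c(=O)[nH]c1=O` differs from compound 2 in one place: hept-1-yn-1-yl in place of nitro on an aromatic carbon. Among the measured compounds shown here, no step between measured compounds covers this change, so the expected size rests on the reference alone. Compound 2 gives a strong result in this assay, and the move to a hept-1-yn-1-yl group in place of nitro is expected to weaken it by a moderate step, a 77-fold higher number from compound 2 to compound 4 (1.89 log units; beyond the scatter). Compound 4 is therefore estimated at 10000 nM, within a range from 1000 nM to 100000 nM.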

Compound 4, half-maximal inhibitory concentration: > 200000 nM
Compound 4: a limit, no number; the forecaster's own chance of this, stated with the estimate: 10%; at least 20-fold (1.30 log units) between middle value and limit.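

At this aromatic carbon, hept-1-yn-1-yl in place of nitro gives an at least 1500-fold higher number from compound 2 to compound 4 (3.18 log units; beyond the scatter) in this assay, so the result depends strongly on what the position carries, and the strong result seen with nitro does not survive this change. For compound 4, > 200000 nM is a limit and not a number. That limit is not unique among the compounds shown: the limit of > 200000 nM in this assay, at which 2 of the 4 values shown sit.

As far as these compounds go, it remains open whether a shorter chain such as ethynyl or propyl, a halogen such as bromine, or an amine on this carbon would keep the strong result. This single change also cannot separate the part played by the triple bond, the part played by the length of the chain and the part played by the loss of nitro itself.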